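Compound 2 to compound 3: adding (dimethylamino)methyl

A few compounds are considered here, and "the series" means these few. Any claim that something is new, unique, unknown or untested is made for them only; others in the source may bear on it.

Within the data shown here, in a functional assay on PC-6 cells (Homo sapiens) for cytotoxicity, read by MTT assay, with a stated time of 3 days (on this read-out lower numbers stand for stronger inhibition and higher numbers for weaker inhibition), compound 2 (`CC(C)(C)c1cc2c(N/N=C/c3ccccc3)ncnc2s1`) gives 6.54 ug/mL, the higher of the two numbers so far and thus the weaker inhibition of the pair. Compound 1 (`CC(C)(C)c1cc2c(N/N=C/c3ccc(CN)cc3)ncnc2s1`) gives 0.214 ug/mL. Among the measured compounds shown here, the only measured step is a 31-fold higher number from compound 1 to compound 2 (1.49 log units; beyond the scatter), which is large and beyond the scatter and comes from hydrogen in place of aminomethyl on an aromatic carbon.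

Compound 3 (`CN(C)Cc1cccc(/C=N/Nc2ncnc3sc(C(C)(C)C)cc23)c1`) departs from compound 2 by (dimethylamino)methyl in place of hydrogen on an aromatic carbon, meta to a large group. The measured step bears on this change only in part, as the entering group is not aminomethyl and a single pair gives no measure of how far the trend carries. Read in reverse, it still points to a lower number in this assay once such a group is present. The expected step is an 8.2-fold lower number from compound 2 to compound 3 (0.91 log units; beyond the scatter), estimated as beyond the scatter but smaller than the measured one. For compound 3 the estimate is 0.8 ug/mL, with an expected range of 0.2 ug/mL to 3.5 ug/mL.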

Compound 3, half-maximal inhibitory concentration: 0.598 ug/mL
Compound 3: middle estimate off by 1.3-fold (0.13 log units), on the high side; measured number inside the range.
By their numbers in this assay, from the lowest: compound 1; then compound 3; then compound 2.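

In this assay, (dimethylamino)methyl in place of hydrogen on an aromatic carbon, meta to a large group, gives an 11-fold lower number from compound 2 to compound 3 (1.04 log units; beyond the scatter). The lower number seen earlier is therefore not confined to aminomethyl: compound 1 and compound 3 each carry a different amine-bearing methyl group, and each stands beyond the scatter from compound 2, which has neither. Nothing measured here explains this step.

Compound 1 and compound 3 differ in more than one place, so the effect of the dimethyl substitution on the nitrogen cannot be separated from that of where the group sits; aminomethyl at the place held by the group in compound 3, or (dimethylamino)methyl at the place held by the group in compound 1, would separate the two. From the compounds shown here alone, it also remains open whether the nitrogen is needed at all, and a plain methyl, a hydroxymethyl or a carboxylic acid at the same carbon would test that against the amines.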